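Swapping a Hydroxylated Side Chain for a Diamino Ring

The source may report more compounds than this note shows. Statements on the series, on what has been measured and on what is new or still open speak of the compounds shown alone.

Measured compounds:
- compound 1 `CCCCCCCCCO[C@@H]1[C@@H](N)[C@@H](OCC(O)CNCCCO)O[C@H](CN)[C@H]1OCCCCCCCCC`: 13.7%
- compound 2 `NC[C@H]1O[C@H](O[C@H]2[C@H](O)[C@@H](OCc3ccc4ccccc4c3)[C@H](N)C[C@@H]2N)[C@H](N)[C@@H](OCc2ccc3ccccc3c2)[C@@H]1O`: 75.9%
- compound 3 `C=CCO[C@H]1O[C@H](CN)[C@@H](OCc2ccc3ccccc3c2)[C@H](OCc2ccc3ccccc3c2)[C@H]1N`: 28.3%

In a toxicity assay on the whole organism (J774 cells) for cytotoxicity, with Mus musculus as the target, read by MTT assay, with a stated time of 24 h, tested at 30 uM (a lower number here means a stronger effect, a higher number a weaker effect of the compound at the concentration tested), compound 1 gives 13.7%, the lowest of the three numbers, and so the strongest effect seen here. Compound 3 is the nearest, with a number higher by a margin beyond the scatter, and compound 2 is furthest away, its number higher by a margin well beyond the scatter.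

Compound 4 `CCCCCCCCCO[C@@H]1[C@@H](N)[C@@H](O[C@H]2[C@H](O)[C@@H](O)[C@H](N)C[C@@H]2N)O[C@H](CN)[C@H]1OCCCCCCCCC` has not been measured. It differs from compound 1 in one place: 4,6-diamino-2,3-dihydroxycyclohexyl in place of 2-hydroxy-3-((3-hydroxypropyl)amino)propyl on an oxygen on a saturated carbon. The two nonyl chains on the shared core are kept.

Among the compounds with values here, no measured pair shows this exact step, so the expectation rests on the numbers of compounds 1, 2 and 3 and on the change itself. Compound 2, which carries the same diamino-dihydroxycyclohexyl unit on its core, sits far above compounds 1 and 3; this makes a move toward a weaker effect plausible, but the other groups in compound 2 are different, so the step is expected to be modest. For compound 4 a step of a number 11.3 percentage points higher from compound 1 to compound 4 (beyond the scatter) is expected in this assay. Compound 4 is estimated at 25%, with a range from 10% to 50%.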

Compound 4, a percentage reported as activity, at one concentration (the size of the read-out at that concentration, not a potency): 48.6%
Beside the measured number, compound 4's estimate is 23.6 percentage points below it; the measured number falls inside the stated range.
By their numbers in this assay, from the lowest: compound 1; then compound 3; then compound 4; then compound 2.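

In this assay, within the data shown here, the 4,6-diamino-2,3-dihydroxycyclohexyl ring in place of the open 2-hydroxy-3-((3-hydroxypropyl)amino)propyl chain gives a number 34.9 percentage points higher from compound 1 to compound 4 (beyond the scatter) and this large step is the first direct reading of this position. With the two nonyl chains kept, the group on this oxygen alone is enough to move the read-out clearly towards a weaker effect, so the position is far from silent. Nothing available explains the shift.

As far as these compounds go, it stays open whether the ring itself, its two amino groups or its hydroxyl groups carry the step. A plain cyclohexyl ring, or a simple chain ending in a primary amine, on the same oxygen could begin to separate these possibilities.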